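The source may report more compounds than this note shows. Statements on the series, on what has been measured and on what is new or still open speak of the compounds shown alone.

Measured compounds in an assay on HEK293 cells for displacement of a labelled ligand from NPC1-like intracellular cholesterol transporter 1 (Homo sapiens); on this read-out higher numbers stand for weaker inhibition and lower numbers for stronger inhibition:

Compound 1 `CC(C)(C)OC(=O)NCCNC(=O)CN1CN(c2ccccc2)C2(CCN(C(=O)c3ccc(C(C)(C)C)cc3)CC2)C1=O`, giving 10900 nM.
Compound 2 `CC(C)(C)c1ccc(C(=O)N2CCC3(CC2)C(=O)N(CC(=O)NCCN)CN3c2ccccc2)cc1`, giving 7000 nM.
Compound 3 `CC(C)(C)OC(=O)NCCCCCNC(=O)CN1CN(c2ccccc2)C2(CCN(C(=O)c3ccc(C(C)(C)C)cc3)CC2)C1=O`, giving 13700 nM.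

Compound 2 shows the lowest of the three numbers, yet its nearest neighbour is compound 1, and the step of a 1.6-fold lower number from compound 1 to compound 2 (0.19 log units; within the scatter) lies within the scatter, as does the step of a 2.0-fold higher number from compound 2 to compound 3 (0.29 log units; within the scatter) to the furthest compound. Compound 4 `CC(C)(C)c1ccc(C(=O)N2CCC3(CC2)C(=O)N(CC(=O)N2CCC(O)CC2)CN3c2ccccc2)cc1` differs from compound 2 by 4-hydroxypiperidin-1-yl in place of (2-aminoethyl)amino on a carbonyl carbon. For the measured compounds named here, none of the measured steps makes exactly this change; all three alter the same end of the chain and all stay within the scatter: a 1.6-fold lower number from compound 1 to compound 2 (0.19 log units; within the scatter), a 1.3-fold higher number from compound 1 to compound 3 (0.10 log units; within the scatter) and a 2.0-fold higher number from compound 2 to compound 3 (0.29 log units; within the scatter). On that basis the change in this assay is expected to be small, with no direction beyond the scatter; the expected step reads a 1.4-fold higher number from compound 2 to compound 4 (0.15 log units; within the scatter). Compound 4 is therefore estimated at 10000 nM, with a range from 3500 nM to 30000 nM.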

Compound 4, half-maximal inhibitory concentration: 4700 nM
Compound 4: middle estimate off by 2.1-fold (0.33 log units), on the high side; the range from low to high includes it.
By their numbers in this assay, from the lowest: compounds 4, 2, 1 and 3 (each within the scatter of the next, the first and the last beyond it).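

In this assay, the step of a 1.5-fold lower number from compound 2 to compound 4 (0.17 log units; within the scatter) shows that this carbonyl carbon can carry 4-hydroxypiperidin-1-yl, with its six-membered non-aromatic ring, in place of the open-chain (2-aminoethyl)amino without a change beyond the scatter. Measured against the tert-butoxycarbonyl-protected chain, the same position gives a 2.3-fold lower number from compound 1 to compound 4 (0.37 log units; beyond the scatter), a modest step but the first listed here to pass beyond the scatter, whereas the earlier chain changes all stayed within it. Nothing available accounts for either step.

The compounds shown leave open how much of this result belongs to the ring and how much to its hydroxyl group. Neither a plain piperidin-1-yl nor a morpholin-4-yl on this carbonyl carbon is among them, so the two contributions cannot be separated.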